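This account rests on a few compounds, and the source may have more. Where it says the series, first, only, none or still open, it means among the compounds named here.

Going by the values given here, only two compounds have been tested so far, so the picture is small. In a functional assay on HeLa cells (Homo sapiens) for cytotoxicity, read by MTT assay, with a stated time of 7 h (a higher number here means a weaker inhibitor, a lower number a stronger inhibitor), compound 1 `NCCNC(=S)Nc1ccnc2cc(Cl)ccc12` gives 18000 nM. This is the lower of the two numbers, which makes it the stronger of the pair. Compound 2 `CCOC(=O)N1CCN(C(=S)Nc2ccnc3cc(Cl)ccc23)CC1`, built on the shared core, gives 40100 nM, and the gap between the two lies beyond the usual scatter.

The next compound to follow is compound 3 `CCN(CC)CCCNC(=S)Nc1ccnc2cc(Cl)ccc12`. It keeps the core of compound 1 and changes only the end of the chain, with (diethylamino)methyl in place of amino on a saturated chain carbon, two bonds along the chain from an amide-type nitrogen. Read one bond further out, this is aminomethyl exchanged for 2-(diethylamino)ethyl.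

Among the compounds with values here, no measured pair shows this exchange, so any forecast rests on very little. The expected change, a 1.5-fold lower number from compound 1 to compound 3 (0.18 log units; within the scatter), is a small step toward a lower number that stays within the usual scatter. For compound 3 the estimated value is 12000 nM, with an expected range from 4000 nM to 35000 nM.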

Compound 3, half-maximal inhibitory concentration: 49200 nM
For compound 3 the middle estimate is 4.1-fold (0.61 log units) below the measured one; the whole stated range lies below it.
By their numbers in this assay, from the lowest: compound 1; then compounds 2 and 3 (each within the scatter of the next).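

In this assay, replacing amino with (diethylamino)methyl on a saturated chain carbon, two bonds along the chain from an amide-type nitrogen, gives a 2.7-fold higher number from compound 1 to compound 3 (0.44 log units; beyond the scatter), a modest step toward weaker activity. Going by these compounds alone, this is the first measured step at this end of the chain, and it shows that the end group of compound 1 cannot be enlarged here without a cost, at least in this one exchange. The change alters several things at once, since the entering group has 6 heavy atoms against 1 for the group that leaves and 0 hydrogen-bond donors against 1, and no measurement available here explains the rise in the number.

On these data alone, what remains open is whether the loss follows the longer chain or the two ethyl groups on its nitrogen. A 2-aminoethyl group, which keeps the plain amine at the end of a longer chain, or a smaller (dimethylamino)methyl group at the same place would help separate those two changes, and a carboxylic acid at the chain end would test a quite different kind of group.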